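The source may hold more compounds than are shown below. What is called first, only, known or untested is meant among the compounds shown, and "the series" means these compounds.

Compound 1 `O=C(Nc1cc(-c2ccccn2)n[nH]1)N1CCC(c2ccc(Cl)cc2)CC1`: > 55000 nM
Compound 2 `O=C(NCc1ccccc1)Nc1[nH]nc(-c2ccccn2)c1Cl`: > 64000 nM
Compound 3 `CC(C)Oc1cc(C(=O)Nc2cc(-c3ccccn3)n[nH]2)cc(C(=O)N2CCCC2)c1`: > 40300 nM

All three compounds were examined in an ADME assay on cells (Peritoneal macrophage cell, Mus musculus) for cytotoxicity, read by fluorescence and resazurin assay, with a stated time of 3 days; a higher number here means that more compound is tolerated, a lower number that less compound is tolerated. For compound 1 the result is only a limit, > 55000 nM, so no number is known for it. Compound 2 likewise stops at a limit, > 64000 nM. Compound 3 also gives only a limit, > 40300 nM. Among the compounds with values here, no measured pair differs in a single place, so no step size can be read off among them; all that can be said is that each of the three sits at a limit rather than at a value.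

Compound 4 `N#Cc1ccc(C2CCN(C(=O)Nc3cc(-c4ccccn4)n[nH]3)CC2)cc1` is the untested partner of compound 1. The two differ in one spot: cyano in place of chloro on an aromatic carbon. Given that compound 1 sits at a limit in this assay, the step from compound 1 to compound 4 is expected to be none beyond the scatter, a step that the limit leaves unreadable from compound 1 to compound 4. Compound 4 is therefore estimated at 60000 nM, within 20000 nM to 200000 nM.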

Compound 4, half-maximal cytotoxic concentration: > 64000 nM
Compound 4: no number, only a limit; the forecaster's own chance of this, stated with the estimate: 85%; middle value at least 1.0-fold (0.02 log units) away from the limit.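

No step can be read between compound 1 and compound 4 in this assay: both results are limits, not numbers. The compounds shown leave open the half-maximal cytotoxic concentration of each of the four.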